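Thiazole in Place of Pyrimidine on the Amine Nitrogen

A few compounds are considered here, and "the series" means these few. Any claim that something is new, unique, unknown or untested is made for them only; others in the source may bear on it.

In a functional assay on NCI-H3122 cells (Homo sapiens) for antiproliferative activity, read by MTT assay, with a stated time of 48 h (on this read-out higher numbers stand for weaker inhibition and lower numbers for stronger inhibition), compound 1 `CC(Oc1cccnc1Nc1cnn(C)c1)c1cccc(C(=O)NCc2ccc(F)cc2)c1` gives 43800 nM. Compound 2 `Cc1ccc(CNC(=O)c2cccc(C(C)Oc3cccnc3Nc3ncccn3)c2)cc1` differs from compound 1 in more than one place, so the two are not set side by side as a single step. In this assay compound 2 reaches only a limit, > 100000 nM, which marks the edge of what the measurement can report rather than a number. That boundary is the one described by the limit of > 100000 nM in this assay, at which 1 of the 2 values shown sits. Compound 3 `Cc1ccc(CNC(=O)c2cccc(C(C)Oc3cccnc3Nc3nccs3)c2)cc1` has not yet been measured; it arises from compound 2 through the change (1,3-thiazol-2-yl in place of pyrimidin-2-yl on a nitrogen on an aromatic ring). Going by the values given here, because compound 2 sits at a limit, no measured step shows how such a swap plays out, and the size of the move can only be guessed. If anything, a modest shift toward stronger inhibition is expected, and the expected step is an at least 1.4-fold lower number from compound 2 to compound 3 (0.15 log units; that floor lies within the scatter). Compound 3 is expected to give 70000 nM in this assay, with a range from 20000 nM to 200000 nM, and a real chance that it too is reported only as a limit.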

Compound 3, half-maximal inhibitory concentration: 15300 nM
Compound 3: middle estimate off by 4.6-fold (0.66 log units), on the high side; measured number below the stated range.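

In this assay, replacing pyrimidin-2-yl with 1,3-thiazol-2-yl on a nitrogen on an aromatic ring gives an at least 6.5-fold lower number from compound 2 to compound 3 (0.81 log units; beyond the scatter), so the first step read at this position shows that this one swap alone can move the result beyond the usual scatter. Compound 2 gives > 100000 nM, which is a limit of the assay and not a number. The step therefore gives only a minimum size, and its true size stays unknown because one of its two ends is that limit: the limit of > 100000 nM in this assay, at which 1 of the 3 values shown sits.

Going by these compounds alone, these compounds hold only one swap on this nitrogen, so they cannot separate the effect of the sulfur atom from that of the change from a six-membered to a five-membered ring, and they cannot show whether a group such as oxazol-2-yl or plain phenyl would do better or worse. Compound 1 carries a different group on this nitrogen but also differs in another place, which leaves open how its group would behave on the frame of compound 3.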